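The source may hold more compounds than are shown below. What is called first, only, known or untested is meant among the compounds shown, and "the series" means these compounds.

In a functional assay on BGC-823 cells (Homo sapiens) for antiproliferative activity, read by MTT assay, with a stated time of 48 h (on this read-out lower numbers stand for stronger inhibition and higher numbers for weaker inhibition), compound 1 (`Fc1ccccc1CSc1nnc(-c2ccc3c(c2)OCCO3)o1`) gives 29000 nM as its result, and compound 2 (`Clc1ccc(CSc2nnc(-c3ccc4c(c3)OCCO4)o2)cc1`) gives 22600 nM as its result. These two numbers lie within the scatter of each other, so compound 2 cannot yet be told apart from compound 1. Compound 3 (`Clc1ccccc1CSc1nnc(-c2ccc3c(c2)OCCO3)o1`) has the same atoms as compound 2, joined differently. The change is 2-chlorophenyl in place of 4-chlorophenyl on a saturated chain carbon bound to a sulfur and in words it puts 2-chlorophenyl in place of 4-chlorophenyl on a saturated chain carbon bound to a sulfur. Going by the values given here, only one measured step bears on this change, namely a 1.3-fold lower number from compound 1 to compound 2 (0.11 log units; within the scatter) and it swaps 2-fluorophenyl for 4-chlorophenyl at that same place. Among the compounds with values here, no measurement yet shows what moving the chlorine alone does. With that single small step as the guide, no step beyond the scatter is expected in this assay and neither direction is favoured. The expected move is a 1.1-fold higher number from compound 2 to compound 3 (0.04 log units; within the scatter) and it amounts to no real change. Compound 3 is estimated at about 25000 nM with an expected range from 11000 nM to 50000 nM on this read-out.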

Compound 3, half-maximal inhibitory concentration: 22500 nM
Estimate against measurement, compound 3: 1.1-fold (0.05 log units) above; low and high end bracket the measured number.
By their numbers in this assay, from the lowest: compounds 3, 2 and 1 (each within the scatter of the next).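

Moving the chlorine alone gives a 1.0-fold lower number from compound 2 to compound 3 (0.00 log units; within the scatter) in this assay and so shows that 4-chlorophenyl and 2-chlorophenyl cannot be told apart at this place on a saturated chain carbon bound to a sulfur. The earlier pair could not show this, since its step changed both the halogen and where it sits on the ring. Exchanging only the halogen gives a 1.3-fold lower number from compound 1 to compound 3 (0.11 log units; within the scatter) and so adds that chloro in place of fluoro on an aromatic carbon also stays within the scatter, and no measured property of these groups is available to explain the flat result.

From the compounds shown here alone, all three compounds carry one halogen on the phenyl ring and the same link to the sulfur, so it remains open whether an amine or a carboxylic acid on that ring, or a longer chain in place of the single carbon, would shift the number beyond the scatter. Going by these compounds, the shared core is also the same throughout, so the effect of any change there on the result in this assay remains unknown.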